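The source may report more compounds than this note shows. Statements on the series, on what has been measured and on what is new or still open speak of the compounds shown alone.

Three compounds sharing one core have been examined in an ADME assay on HFF cells (Homo sapiens) for cytotoxicity, with a stated time of 8 days; on this read-out lower numbers stand for higher toxicity in this test and higher numbers for lower toxicity in this test. Compound 1 `CNc1nc(N)nc2c1ncn2/C=C1/CC1(CO)CO` gives 265000 nM. Compound 2 `Nc1nc(OCC(F)(F)F)c2ncn(/C=C3/CC3(CO)CO)c2n1` reaches only the ceiling of the test, a limit of > 300000 nM, so no exact number stands for it. Compound 3 `CCCCCCCCOc1nc(N)nc2c1ncn2/C=C1/CC1(CO)CO` likewise stops at the limit of > 300000 nM. Where compound 2 sits is thus known only as the limit of > 300000 nM in this assay, at which 2 of the 3 values shown sit.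

Compound 4 `CCCCCCSc1nc(N)nc2c1ncn2/C=C1/CC1(CO)CO` differs from compound 2 in one place: hexylsulfanyl in place of 2,2,2-trifluoroethoxy on an aromatic carbon. The measured steps that bear on it start from compound 1: an at least 1.1-fold higher number from compound 1 to compound 2 (0.05 log units; that floor lies within the scatter), and an at least 1.1-fold higher number from compound 1 to compound 3 (0.05 log units; that floor lies within the scatter), both ending at the limit. Between the two limit compounds, a step that the two limits leave unreadable from compound 2 to compound 3, so an exchange of one side chain for another cannot be sized here. Compound 3, carrying a long hydrocarbon chain, stays at the limit of > 300000 nM, and the hexylsulfanyl chain of compound 4 resembles that octyloxy chain more than the trifluoroethoxy group it replaces. The account therefore expects no step beyond the scatter, an estimated a number no higher from compound 2 to compound 4 (the limit leaves the size open). Compound 4 is expected to give about 300000 nM, most likely reported once more as a limit rather than a number.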

Compound 4, half-maximal cytotoxic concentration: > 300000 nM
Compound 4: only a limit was reported; the forecaster's own chance of this, stated with the estimate: 60%; the middle value sits exactly at the limit.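

Hexylsulfanyl is the first group shown on this aromatic carbon that is joined through sulfur, and with it the read-out in this assay still ends at the ceiling of the test, as it did with the oxygen-linked groups of compound 2 and compound 3. Within the data shown here, the only step with a readable floor is an at least 1.1-fold higher number from compound 1 to compound 4 (0.05 log units; that floor lies within the scatter), while the steps among compound 2, compound 3 and compound 4 cannot be read, since all three values are limits. This position has now carried three different side groups with the same outcome: the limit of > 300000 nM in this assay, at which 3 of the 4 values shown sit.

The compounds shown leave open how far past the ceiling compound 2, compound 3 and compound 4 lie, and so whether the sulfur link or the length of the chain makes any difference in this test. They also leave open whether a carboxylic acid, a tertiary amine or a shorter alkyl chain on this aromatic carbon would give an exact number, like compound 1 with 265000 nM.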